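Ring Nitrogen Methylation in a Bridged Amine Series

This account rests on a few compounds, and the source may have more. Where it says the series, first, only, none or still open, it means among the compounds named here.

Measured compounds:
compound 1, `Clc1ccncc1C1=CC2CNCC(C1)C2`, in an in vitro assay on SH-EP1 cells for displacement of a labelled ligand from Neuronal acetylcholine receptor; alpha4/beta2 (Homo sapiens); on this read-out lower numbers stand for stronger inhibition and higher numbers for weaker inhibition: 3 nM
compound 2, `CN1CC2C=C(c3cnccc3Cl)CC(C2)C1`, in this assay: 1160 nM
compound 3, `CC(C)Oc1cncc(C2=CC3CNCC(C2)C3)c1`, in this assay: 0.26 nM

Compound 1 and compound 2 share a core and differ in one place: methyl in place of hydrogen on an amine nitrogen in a ring. In this assay this single change gives a 390-fold higher number from compound 1 to compound 2 (2.59 log units; beyond the scatter), a large movement toward weaker binding. Compound 3 carries a different core; how it differs from the core of compound 1 is not broken down here. Among the three measured compounds, compound 3 gives the lowest number in this assay, and its steps to compound 1 and to compound 2 both lie beyond the scatter.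

Compound 4, `CC(C)Oc1cncc(C2=CC3CC(C2)CN(C)C3)c1`, is not yet measured. It is derived from compound 3 by methyl in place of hydrogen on an amine nitrogen in a ring. Among the measured compounds shown here, this is the same change, at the same place, as the one from compound 1 to compound 2. Within this series the change has been seen once, so the expectation rests on a single pair.

For the measured compounds named here, for compound 4 the step is estimated as a 350-fold higher number from compound 3 to compound 4 (2.54 log units; beyond the scatter), because the only precedent is a 390-fold higher number from compound 1 to compound 2 (2.59 log units; beyond the scatter). In this assay compound 4 is therefore expected to give about 90 nM, with a likely range from 15 nM to 500 nM. The wide range reflects that the precedent comes from one pair on a different core.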

Compound 4, inhibition constant: 2.2 nM
Beside the measured number, compound 4's estimate is 41-fold (1.61 log units) above it, outside the stated range (below it).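

In this assay, methyl in place of hydrogen on an amine nitrogen in a ring again moves the number toward weaker binding on the second core, giving an 8.5-fold higher number from compound 3 to compound 4 (0.93 log units; beyond the scatter), so the direction of the step is the same in both pairs shown. The size of the step does not carry over from one core to the other, and the gap between the two steps is larger than measurement scatter alone would account for: the same change on two cores in this assay, a 390-fold higher number (2.59 log units; beyond the scatter) from compound 1 to compound 2 and an 8.5-fold higher number (0.93 log units; beyond the scatter) from compound 3 to compound 4, 46-fold (1.66 log units) apart, beyond the scatter of two such steps. This shows that, in this series, the size of the step depends on the setting in which the change is made, so one pair is a poor guide to its size on another core; it does not show which structural difference between the two cores sets that size, or why the two steps differ.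

As far as these compounds go, it remains open whether ethyl or a longer chain in place of this methyl on the same amine nitrogen would give a large step on one core and a modest step on the other, as methyl does. From the compounds shown here alone, it also remains open whether the same methyl change on a third core would fall near either of these two steps or somewhere between them.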